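The compounds below may be only part of what the source reports. "The series", "measured", "known", "first", "only" and "open" are said of these compounds alone.

In an ADME assay on HUVEC cells (Homo sapiens) for cytotoxicity, read by MTT assay, with a stated time of 72 h (a lower number here means a stronger inhibitor, a higher number a weaker inhibitor), compound 1 `COc1cc(-c2nccn2C(C)C)cc(OC)c1OC` has "not determined" (no result reported) as its entry, and compound 2 `CCCCCn1ccnc1-c1cc(OC)c(OC)c(OC)c1` has "not determined" (no result reported) as its entry. Compound 3 `COc1cc(-c2nccn2-c2cccc(C)c2)cc(OC)c1OC` gives > 100000 nM as a limit of the assay and not a number. Within the data shown here, the evidence so far comes down to the limit of > 100000 nM in this assay, at which 1 of the 3 values shown sits, and no more, and no step between measured compounds is available for comparison.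

Compound 4 `COc1cc(-c2nccn2-c2ccc(Br)cc2)cc(OC)c1OC` carries 4-bromophenyl in place of 3-methylphenyl on an aromatic nitrogen, the change being 4-bromophenyl in place of 3-methylphenyl on an aromatic nitrogen with the rest of the shared core untouched. Compound 3 with > 100000 nM as its limit is the only anchor, so in this assay a step no larger than the usual scatter is expected, in no firm direction. The estimated change is a number no higher from compound 3 to compound 4 (the limit leaves the size open) in size, which stays within that scatter. For compound 4 the expected value is 100000 nM with an estimated range from 30000 nM to 200000 nM and a fair chance of only a limit.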

Compound 4, half-maximal inhibitory concentration: > 100000 nM
Compound 4 gave a limit, no number (the forecaster's own chance of this, stated with the estimate: 60%); the middle value sits exactly at the limit.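

No step can be read between compound 3 and compound 4, as both entries in this assay are limits of the assay and not numbers: the limit of > 100000 nM in this assay, at which 2 of the 4 values shown sit.

The compounds shown leave open whether any group on that aromatic nitrogen gives a readable half-maximal inhibitory concentration in this assay.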